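This account rests on a few compounds, and the source may have more. Where it says the series, first, only, none or still open, it means among the compounds named here.

In a functional assay on SHEP cells (Homo sapiens) for antiproliferative activity, read by spectrophotometry and resazurin assay, with a stated time of 72 h (on this read-out lower numbers stand for stronger inhibition and higher numbers for weaker inhibition), compound 1 (`CC(C)CC(=O)CC1Oc2cc(O)ccc2C=C1c1ccc(O)cc1`) gives 139000 nM and compound 3 (`O=C(CC1Oc2cc(O)ccc2C=C1c1ccc(O)cc1)c1ccc(Cl)cc1`) gives 167000 nM while compound 2 (`COc1ccc(C(=O)CC2Oc3cc(O)ccc3C=C2c2ccc(O)cc2)cc1`) gives 37000 nM as the lowest of the three. Compound 1 thus stands level with compound 3 within the scatter. Compound 4 (`Cc1cc(C2Oc3cc(O)ccc3C=C2c2ccc(O)cc2)cc(C)c1N`) carries 4-amino-3,5-dimethylphenyl in place of (isobutylcarbonyl)methyl on a saturated ring carbon. The measured steps are (a 1.2-fold higher number from compound 1 to compound 3 (0.08 log units; within the scatter)), (a 3.8-fold lower number from compound 1 to compound 2 (0.57 log units; beyond the scatter)) and (a 4.5-fold higher number from compound 2 to compound 3 (0.65 log units; beyond the scatter)). All three keep the carbonyl that compound 4 lacks, and they bear on it only loosely. Compound 2, an aryl case at 37000 nM in this assay, suggests the direction, and a lower number is expected, estimated as (a 7.0-fold lower number from compound 1 to compound 4 (0.84 log units; beyond the scatter)). The expected value for compound 4 is 20000 nM with a range from 4000 nM to 100000 nM as the upper end.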

Compound 4, half-maximal inhibitory concentration: 102000 nM
The estimate for compound 4 lay 5.1-fold (0.71 log units) below the measured number, outside the stated range (above it).
By their numbers in this assay, from the lowest: compound 2; then compounds 4, 1 and 3 (each within the scatter of the next).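

On the saturated ring carbon, 4-amino-3,5-dimethylphenyl in place of (isobutylcarbonyl)methyl gives a 1.4-fold lower number from compound 1 to compound 4 (0.13 log units; within the scatter). For the compounds shown here, the position thus accepts an aromatic ring without the carbonyl that the earlier compounds all keep, and the number stays level with that of compound 1. Nothing shown here explains this result. As far as these compounds go, it remains open whether 4-methoxyphenyl without the carbonyl would give a number like that of compound 2, and whether a carboxylic acid or a longer chain at this position would move the number at all.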